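Swapping a carbamoyl for an ethyl on a piperidine ring

A few compounds are considered here, and "the series" means these few. Any claim that something is new, unique, unknown or untested is made for them only; others in the source may bear on it.

Measured compounds:
compound 1, `CCOC(=O)C1CCN(C(=O)CN2CN(c3ccccc3)C3(CCN(C(=O)c4ccc(C5CCCCC5)cc4)CC3)C2=O)CC1`, 900 nM
compound 2, `CC(C)(C)c1ccc(C(=O)N2CCC3(CC2)C(=O)N(CC(=O)NCCO)CN3c2ccccc2)cc1`, 1000 nM
compound 3, `CC(C)(C)c1ccc(C(=O)N2CCC3(CC2)C(=O)N(CC(=O)N2CCCC(C(N)=O)C2)CN3c2ccccc2)cc1`, 16900 nM

All three share one core, and each was tested in an assay on HEK293 cells for displacement of a labelled ligand from NPC1-like intracellular cholesterol transporter 1 (Homo sapiens); on this read-out higher numbers stand for weaker inhibition and lower numbers for stronger inhibition. Compound 3 gives the highest number of the three in this assay: compound 2 sits well below it, as does compound 1, and both gaps are beyond the scatter. Going by the values given here, the single measured step that leads to compound 3 is a 17-fold higher number from compound 2 to compound 3 (1.23 log units; beyond the scatter), a large loss that came with the exchange of a small open-chain group for a ring bearing a carbamoyl.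

Compound 4, `CCC1CCCN(C(=O)CN2CN(c3ccccc3)C3(CCN(C(=O)c4ccc(C(C)(C)C)cc4)CC3)C2=O)C1`, keeps that ring but changes the group on it: ethyl in place of carbamoyl on a saturated ring carbon. Among the compounds with values here, no measured pair shows this particular exchange, so the expectation rests on what the three numbers show. Compound 1, whose ring carries an ester rather than a carbamoyl, and compound 2 both gave far lower numbers than compound 3 in this assay. On that basis compound 4 is expected to move back toward them, but how far cannot be read from these data. A moderate improvement, a 2.8-fold lower number from compound 3 to compound 4 (0.45 log units; beyond the scatter), is expected, with wide uncertainty. Compound 4 is therefore estimated at 6000 nM, in a range from 1500 nM to 20000 nM.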

Compound 4, half-maximal inhibitory concentration: 3900 nM
For compound 4 the middle estimate is 1.5-fold (0.19 log units) above the measured one; measured number inside the range.
By their numbers in this assay, from the lowest: compounds 1 and 2 (each within the scatter of the next); then compound 4; then compound 3.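

Exchanging the carbamoyl for ethyl on this saturated ring carbon, two ring bonds from the ring nitrogen, gives in this assay a 4.3-fold lower number from compound 3 to compound 4 (0.64 log units; beyond the scatter), so the group at this one place changes the number even when the ring around it stays the same. Yet the gap to the open-chain group is not fully closed: replacing (2-hydroxyethyl)amino with 3-ethylpiperidin-1-yl gives a 3.9-fold higher number from compound 2 to compound 4 (0.59 log units; beyond the scatter), which means that the large loss seen with 3-carbamoylpiperidin-1-yl is only partly undone by removing the carbamoyl. Nothing shown here explains why these two groups give different numbers at this position.

The compounds shown leave open whether a piperidine with no group at this ring carbon, or one carrying a methyl, a hydroxymethyl or a carboxylic acid, would come closer to compound 2 on this read-out. They also leave open whether a longer chain such as propyl in place of ethyl would lower the number further or raise it again.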